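The source may report more compounds than this note shows. Statements on the series, on what has been measured and on what is new or still open speak of the compounds shown alone.

In a functional assay on the whole organism for inhibition, with Rattus norvegicus as the target (on this read-out lower numbers stand for stronger inhibition and higher numbers for weaker inhibition), compound 1 `O=C1ON=C(c2cccs2)/C1=C/c1ccc(O)cc1` gives 4200 nM. Compound 2 `COc1ccccc1C1=NOC(=O)/C1=C\c1cccs1` gives 7100 nM and compound 3 `O=C1ON=C(c2cccs2)/C1=C/c1ccc(O)c(O)c1` gives 3400 nM, and compound 1 lies within the usual scatter of both. Compound 4 `O=C1ON=C(c2cccs2)/C1=C/c1ccc(F)cc1` has not yet been measured and differs from compound 1 in one place: fluoro in place of hydroxy on an aromatic carbon. The swap is fluoro in place of hydroxy on an aromatic carbon. Among the compounds with values here, the only measured step on that ring leads to compound 3, a 1.2-fold lower number from compound 1 to compound 3 (0.09 log units; within the scatter), with hydroxy in place of hydrogen. That is a different change, so it offers only indirect guidance, and no step beyond the scatter is expected. The expected step is a 1.2-fold higher number from compound 1 to compound 4 (0.08 log units; within the scatter). For compound 4 the estimated value is 5000 nM, with an expected range of 2000 nM to 12000 nM.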

Compound 4, half-maximal inhibitory concentration: 4800 nM
For compound 4 the middle estimate is 1.0-fold (0.02 log units) above the measured one; measured number inside the range.
By their numbers in this assay, from the lowest: compounds 3, 1, 4 and 2 (each within the scatter of the next, the first and the last beyond it).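

In this assay, fluoro in place of hydroxy gives a 1.1-fold higher number from compound 1 to compound 4 (0.06 log units; within the scatter). Within the data shown here, compound 3 kept this hydroxy, so this is the first view of the position without it: on an aromatic carbon para to a large group, a fluoro with no hydrogen-bond donor or acceptor stands within the scatter of the hydroxy, which has one of each. Nothing shown explains this result.

The compounds shown place only hydroxy and fluoro here. As far as these compounds go, how an amine, a carboxylic acid or a longer chain at this position would read remains open.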